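Phenyl replaces anilino on the carbonyl of compound 2

The source may hold more compounds than are shown below. What is called first, only, known or untested is meant among the compounds shown, and "the series" means these compounds.

Compound 1 `CC(=O)/N=C1\NC2(CCCCO2)CCS1` gives 3.1 mg/kg in a functional assay on the whole organism (strain CF-1) with Mus musculus as the target, in the writhing test, with a stated time of 15 min; on this read-out lower numbers stand for an effect already at smaller amounts and higher numbers for an effect only at larger amounts of compound. Compound 2 `O=C(/N=C1\NC2(CCCCO2)CCS1)Nc1ccccc1` gives only a limit in this assay, > 200 mg/kg. Compound 3 `O=C(/N=C1\NCCCS1)c1ccc(F)cc1` likewise gives only a limit, > 100 mg/kg. For the measured compounds named here, the one fully measured step, an at least 64-fold higher number from compound 1 to compound 2 (1.80 log units; beyond the scatter), is the anilino in place of methyl on the carbonyl carbon. Compound 2 therefore stands at the limit of > 200 mg/kg in this assay, at which 1 of the 3 values shown sits, and compound 3 at the limit of > 100 mg/kg in this assay, at which 1 of the 3 values shown sits. Compound 4 `O=C(/N=C1\NC2(CCCCO2)CCS1)c1ccccc1` differs from compound 2 by phenyl in place of anilino on a carbonyl carbon, which removes the urea-type linkage that came in on the measured step. The expected step of an at least 3.3-fold lower number from compound 2 to compound 4 (0.52 log units; beyond the scatter) is a modest recovery, though compound 3 with its aroyl group on a related core tempers this. Compound 4 is expected at 60 mg/kg, in the range 10 mg/kg to 300 mg/kg.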

Compound 4, dose for half-maximal effect: 5 mg/kg
Compound 4: the middle estimate sits 12-fold (1.08 log units) above what was measured; the measured number lies below the stated range.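

In this assay, the carbonyl carbon accepts an aromatic ring without the loss seen with anilino, and phenyl in place of anilino gives an at least 40-fold lower number from compound 2 to compound 4 (1.60 log units; beyond the scatter). Compound 2 is held only at a limit: the limit of > 200 mg/kg in this assay, at which 1 of the 4 values shown sits. Phenyl and methyl at this place are not separated, with a 1.6-fold higher number from compound 1 to compound 4 (0.21 log units; within the scatter).

Open, going by these compounds, is whether benzyl or a longer alkyl chain on this carbonyl carbon would keep the number in the same range. Compound 3 differs from compound 4 in more than one place, and what separates them cannot be read from the compounds shown.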